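The source may report more compounds than this note shows. Statements on the series, on what has been measured and on what is new or still open speak of the compounds shown alone.

Measured so far:
compound 1, `COc1ccc(C2=NN(C3=NC(=O)/C(=C4\C(=O)Nc5ccccc54)S3)C(c3ccc(OC)cc3)C2)cc1`, 100000 nM;
compound 2, `COc1ccc(C2=NN(C3=NC(=O)/C(=C4\C(=O)Nc5ccc(Br)cc54)S3)C(c3ccc(OC)cc3)C2)cc1`, 190 nM.

In a functional assay on cells (Melanoma cell, Homo sapiens) for cytotoxicity, read by sulforhodamine B assay, with a stated time of 48 h (on this read-out lower numbers stand for stronger inhibition of growth and higher numbers for weaker inhibition of growth), compound 2 gives 190 nM, the lowest of the two numbers. Going by the values given here, its only neighbour is compound 1, and the single step between them, a 530-fold lower number from compound 1 to compound 2 (2.72 log units; beyond the scatter), came from putting bromo in place of hydrogen on an aromatic carbon. Compound 3, `COc1ccc(C2=NN(C3=NC(=O)/C(=C4\C(=O)Nc5ccc(Cl)cc54)S3)C(c3ccc(OC)cc3)C2)cc1`, keeps everything else and differs from compound 2 in one detail: chloro in place of bromo on an aromatic carbon. Among the compounds with values here, the bromo-for-hydrogen step is the one measurement that bears on this place, and it was large; exchanging one halogen for another at the same carbon is a smaller change than adding the halogen where none was. Compound 3 is therefore expected to differ little, with an expected step of a 1.6-fold higher number from compound 2 to compound 3 (0.20 log units; within the scatter) that probably stays within the scatter. Compound 3 is estimated at 300 nM, most likely between 100 nM and 1000 nM.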

Compound 3, concentration for 50% growth inhibition: 190 nM
Beside the measured number, compound 3's estimate is 1.6-fold (0.20 log units) above it; the measured number falls inside the stated range.
By their numbers in this assay, from the lowest: compounds 2 and 3 (each within the scatter of the next); then compound 1.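

Replacing one halogen with the other at this carbon gives no change at the digits printed from compound 2 to compound 3 (within the scatter) in this assay so bromo and chloro cannot be told apart here. Chloro in place of hydrogen gives a 530-fold lower number from compound 1 to compound 3 (2.72 log units; beyond the scatter) and this second large step at the same carbon shows that the drop seen with bromo is not unique to bromo. Among these three compounds, what separates the numbers is whether this carbon carries a halogen or a hydrogen, not which of the two halogens it carries.

Nothing available explains why a halogen here has so large an effect. On these data alone, it also remains open whether fluoro, or a non-halogen group such as methyl, methoxy or an amine, at this same carbon would give a number like that of compound 2 or like that of compound 1.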